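The source may report more compounds than this note shows. Statements on the series, on what has been measured and on what is new or still open speak of the compounds shown alone.

Measured compounds in a functional assay on the whole organism with Mus musculus as the target, in the maximal electroshock model; a lower number here means that less compound is needed, a higher number that more compound is needed for the effect:
Compound 1 `Cc1nn2c(-c3ccccc3)nnc2cc1Cc1ccccc1` gives 108 mg/kg.
Compound 2 `Cc1nn2cnnc2cc1Cc1c(Cl)cccc1Cl` gives 6.2 mg/kg.
Compound 3 `Cc1nn2c(C)nnc2cc1Cc1ccccc1Cl` gives 30.5 mg/kg.

Compound 1 needs the highest dose of the three. Compound 3 comes nearest to it, with a lower number that still lies beyond the scatter, and compound 2 lies furthest, also beyond the scatter. Both of these differ from compound 1 in more than one place, so no single step can be read from them. Compound 4 `Cc1nn2c(N)nnc2cc1Cc1ccccc1` differs from compound 1 by amino in place of phenyl on an aromatic carbon. Among the compounds with values here, no measured pair isolates this change. The expected step of a 1.8-fold lower number from compound 1 to compound 4 (0.26 log units; within the scatter) in this assay is a modest decrease in dose, not far beyond the scatter. Compound 4 is therefore estimated at 60 mg/kg, within a range from 20 mg/kg to 200 mg/kg.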

Compound 4, dose for half-maximal effect: 22 mg/kg
For compound 4 the middle estimate is 2.7-fold (0.44 log units) above the measured one; low and high end bracket the measured number.
By their numbers in this assay, from the lowest: compound 2; then compounds 4 and 3 (each within the scatter of the next); then compound 1.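

In this assay, within the data shown here, amino in place of phenyl on the aromatic carbon between two ring nitrogen atoms gives a 4.9-fold lower number from compound 1 to compound 4 (0.69 log units; beyond the scatter), the first change at this position that can be read on its own. The phenyl is therefore not required for the effect, and a single nitrogen in its place goes with a lower dose beyond the scatter. Nothing measured here explains this step.

As far as these compounds go, whether the gain comes from adding the amino or from losing the phenyl remains open. A hydroxyl or a dimethylamino group at this carbon could help separate the two.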